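The source may report more compounds than this note shows. Statements on the series, on what has been measured and on what is new or still open speak of the compounds shown alone.

Among the measured compounds shown here, in an ADME assay on U2OS cells (Homo sapiens) for cytotoxicity, with a stated time of 96 h (a higher number here means that more compound is tolerated, a lower number that less compound is tolerated), two compounds have numbers so far. Compound 1 `COc1ccc(C2CC(=O)C3=C(C2)NC(C)=C(C(=O)OCCc2ccccc2)C3c2ccncc2)cc1` gives 19300 nM, the lower of the two, while compound 2 `Cc1nnc(-c2cccc(-c3ccnc4[nH]ccc34)c2)s1` gives 127000 nM, a gap beyond the usual scatter of repeated measurements. These two structures differ in many places, so the gap cannot be tied to any single part. Compound 3 `CC1=C(C(=O)OCCc2ccccc2)C(c2ccncc2)C2=C(CC(c3ccccc3)CC2=O)N1` stays much closer to compound 1: it carries hydrogen in place of methoxy on an aromatic carbon, para to a large group, turning 4-methoxyphenyl into phenyl (hydrogen in place of methoxy on an aromatic carbon). For the measured compounds named here, no measured pair shows what this change does, so the expectation starts from compound 1 at 19300 nM and assumes little movement. The expected outcome is a 1.1-fold higher number from compound 1 to compound 3 (0.06 log units; within the scatter), which would be no step beyond the scatter. For compound 3 the estimate is 22000 nM, with an expected range from 10000 nM to 48000 nM.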

Compound 3, half-maximal cytotoxic concentration: > 200000 nM
Compound 3 gave a limit, no number; the forecaster's own chance of this, stated with the estimate: 3%; middle value at least 9.0-fold (0.95 log units) from the limit.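

Replacing methoxy with hydrogen on this aromatic carbon, para to a large group, gives an at least 10-fold higher number from compound 1 to compound 3 (1.01 log units; beyond the scatter), so in this assay this one place clearly bears on how much compound the cells tolerate. The gap between the first two compounds could not be tied to any single part, whereas this pair differs in one place only, and the change removes just 2 heavy atoms. Compound 3 gives a limit of the assay and not a number: the limit of > 200000 nM in this assay, at which 1 of the 3 values shown sits.

As far as these compounds go, only methoxy and hydrogen have been compared at this carbon, so it remains open how a hydroxyl, a fluorine or a longer chain such as ethoxy would behave there. The compounds shown also do not reveal why removing methoxy has this effect, or whether methoxy would have the same effect on another carbon of the ring.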